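A Half-Life Still Hidden Behind an Assay Limit

A few compounds are considered here, and "the series" means these few. Any claim that something is new, unique, unknown or untested is made for them only; others in the source may bear on it.

In an ADME assay on microsomes from liver (Rattus norvegicus) for metabolic stability (a lower number here means that the compound disappears faster, a higher number that the compound lasts longer), compound 3 `Nc1nc(NCCNc2ncc(-c3ncc[nH]3)c(-c3ccc(Br)cc3F)n2)ccc1[N+](=O)[O-]` gives > 0.5 h, which is a limit and not a number. Compound 1 `Nc1nc(NCCNc2ncc(-c3ncc[nH]3)c(-c3ccccc3Cl)n2)ccc1[N+](=O)[O-]` also gives only a limit, > 0.5 h. Compound 2 `Nc1nc(NCCNc2ncc(-c3ncc[nH]3)c(-c3ccc(F)cc3Br)n2)ccc1[N+](=O)[O-]` likewise gives only a limit, > 0.5 h. All three therefore sit together: the limit of > 0.5 h in this assay, at which 3 of the 3 values shown sit. Compound 4 `Cc1cc(Cl)ccc1-c1nc(NCCNc2ccc([N+](=O)[O-])c(N)n2)ncc1-c1ncc[nH]1` carries 4-chloro-2-methylphenyl in place of 4-bromo-2-fluorophenyl on an aromatic carbon. The measured changes at this same place, a step that the two limits leave unreadable from compound 1 to compound 3 and a step that the two limits leave unreadable from compound 2 to compound 3, have no readable size and indicate no direction. The expected step is therefore a step that the limit leaves unreadable from compound 3 to compound 4, with nothing foreseen beyond the scatter. For compound 4, the estimated half-life is 0.6 h, with an expected range of 0.3 h to 1.2 h.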

Compound 4, half-life: > 0.5 h
Compound 4: only a limit was reported; the forecaster's own chance of this, stated with the estimate: 65%; the middle value is on the limit's open side.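

Compound 4, like compound 1, compound 2 and compound 3, gives only a limit in this assay, so no new step can be read among them: the limit of > 0.5 h in this assay, at which 4 of the 4 values shown sit. The compounds shown leave open how far each half-life lies past that limit, and whether changing the substituted phenyl group alters it at all.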